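A few compounds are considered here, and "the series" means these few. Any claim that something is new, unique, unknown or untested is made for them only; others in the source may bear on it.

Working notes on the series. The shared core is that of compound 1 `CC(C)C[C@H](N)c1cc(C(F)(F)F)ccc1N1CCN(C(=O)C(C)Cc2ccc(Cl)cc2O)CC1`, which in an assay on HEK293 cells for displacement of a labelled ligand from Melanocortin receptor 4 (Homo sapiens) (on this read-out higher numbers stand for weaker inhibition and lower numbers for stronger inhibition), gives 36 nM. Compound 2 `CC(C)C[C@H](N)c1cc(C(F)(F)F)ccc1N1CCN(C(=O)CCC(=O)N(C)C)CC1` carries 2-(dimethylcarbamoyl)ethyl on the carbonyl carbon; in this assay compound 2 reaches only > 10000 nM, which is a limit of the assay and not a number (the limit of > 10000 nM in this assay, at which 1 of the 3 values shown sits). Compound 3 `CC(C)C[C@H](N)c1cc(C(F)(F)F)ccc1N1CCN(C(=O)COc2cccc(Cl)c2)CC1` carries (3-chlorophenoxy)methyl at the same carbonyl carbon, and in this assay compound 3 gives 2600 nM. Among the numbers so far compound 3 stands highest; its nearest neighbour is compound 1, the gap being a 72-fold higher number from compound 1 to compound 3 (1.86 log units; beyond the scatter). The other steps are an at least 270-fold higher number from compound 1 to compound 2 (2.44 log units; beyond the scatter) and an at least 3.8-fold lower number from compound 2 to compound 3 (0.58 log units; beyond the scatter).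

Compound 4 `CCOc1cccc(CC(C)C(=O)N2CCN(c3ccc(C(F)(F)F)cc3[C@@H](N)CC(C)C)CC2)c1` is the next member. 1-(3-ethoxybenzyl)ethyl in place of (3-chlorophenoxy)methyl on a carbonyl carbon The change thus returns to a group of the same kind as the 1-(4-chloro-2-hydroxybenzyl)ethyl of compound 1, now as 1-(3-ethoxybenzyl)ethyl. The step that bears on it is a 72-fold higher number from compound 1 to compound 3 (1.86 log units; beyond the scatter), large and in the opposite direction; compound 4 is therefore expected to run most of the way back, though the ring substitution differs from that of compound 1. The expected step is a 17-fold lower number from compound 3 to compound 4 (1.24 log units; beyond the scatter). The estimate for compound 4 in this assay is 150 nM, expected to fall between 40 nM and 600 nM.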

Compound 4, inhibition constant: 2200 nM
Compound 4: middle estimate off by 15-fold (1.17 log units), on the low side; measured number outside the range, above it.
By their numbers in this assay, from the lowest: compound 1; then compounds 4 and 3 (each within the scatter of the next). At a limit, above all of these: compound 2.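

In this assay, the kind of chain on the carbonyl carbon does not decide the result by itself: a 1.2-fold lower number from compound 3 to compound 4 (0.07 log units; within the scatter), so 1-(3-ethoxybenzyl)ethyl and (3-chlorophenoxy)methyl cannot be told apart on this read-out. Among the compounds shown here, the ring substitution matters in a way the earlier compounds could not show, since they changed chain and ring together: with the chain kept, 3-ethoxyphenyl in place of 4-chloro-2-hydroxyphenyl gives a 61-fold higher number from compound 1 to compound 4 (1.79 log units; beyond the scatter), a large step from this single change. The remaining step, an at least 4.5-fold lower number from compound 2 to compound 4 (0.65 log units; beyond the scatter), holds only as a bound, its starting value being a limit of the assay and not a number: the limit of > 10000 nM in this assay, at which 1 of the 4 values shown sits.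

The compounds shown leave open whether the step from compound 1 rests on the hydroxy group, on the chloro group, on the ethoxy group or on some combination of these, as all of them differ at once. From the compounds shown here alone, it also remains open how an amine or a carboxylic acid in place of the hydroxy group of compound 1 would read in this assay.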